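This account rests on a few compounds, and the source may have more. Where it says the series, first, only, none or still open, it means among the compounds named here.

Compound 1 `CC1=NNC(=O)C1C(c1c[nH]c2ccccc12)c1c(-c2ccccc2)[nH]c2ccc(C)cc12` gives 3200 nM in a functional assay on HEp-2 cells (Homo sapiens) for cytotoxicity, read by MTT assay; on this read-out lower numbers stand for stronger inhibition and higher numbers for weaker inhibition.
Compound 2 `CC1=NNC(=O)C1C(c1c[nH]c2ccccc12)c1c(-c2ccccc2)[nH]c2ccc(Cl)cc12` gives > 100000 nM, which is a limit of this assay and not a number.
Compound 3 `COc1ccc2[nH]c(-c3ccccc3)c(C(c3c[nH]c4ccccc34)C3C(=O)NN=C3C)c2c1` gives 5300 nM.

Of the two plain numbers, compound 3 stands highest, with compound 1 nearest: the step was a 1.7-fold higher number from compound 1 to compound 3 (0.22 log units; within the scatter). Compound 4 `CC1=NNC(=O)C1C(c1c[nH]c2ccccc12)c1c(-c2ccccc2)[nH]c2ccccc12` differs from compound 3 by hydrogen in place of methoxy on an aromatic carbon. For the measured compounds named here, no measured step removes a group outright. The closest guide is the exchange of one small group for another, methyl for methoxy, which gave a 1.7-fold higher number from compound 1 to compound 3 (0.22 log units; within the scatter), whereas chloro at the same carbon sits at a limit (the limit of > 100000 nM in this assay, at which 1 of the 3 values shown sits). Replacing methoxy with hydrogen is therefore expected to give a step of about a 1.1-fold lower number from compound 3 to compound 4 (0.03 log units; within the scatter), not beyond the scatter. Compound 4 is estimated at 5000 nM, likely between 1500 nM and 30000 nM.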

Compound 4, half-maximal inhibitory concentration: 6700 nM
The estimate for compound 4 lay 1.3-fold (0.13 log units) below the measured number, within the range that was stated.
By their numbers in this assay, from the lowest: compounds 1, 3 and 4 (each within the scatter of the next, the first and the last beyond it). At a limit, above all of these: compound 2.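

Hydrogen in place of methoxy stays within the scatter: a 1.3-fold higher number from compound 3 to compound 4 (0.10 log units; within the scatter). Hydrogen in place of methyl lies just beyond it, a modest step: a 2.1-fold higher number from compound 1 to compound 4 (0.32 log units; beyond the scatter). Compound 2, the chloro compound, stands at a limit and not a number, and the large step to hydrogen shows that an unsubstituted carbon at this position does not share its result: an at least 14-fold lower number from compound 2 to compound 4 (1.17 log units; beyond the scatter).

From the compounds shown here alone, it remains open whether an amine, a carboxylic acid or a longer chain at this carbon would read like hydrogen, methyl and methoxy, or like chloro. Fluoro or bromo would show whether other halogens also read like chloro.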